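Replacing a Ketone with a Plain Propyl Chain

The source may report more compounds than this note shows. Statements on the series, on what has been measured and on what is new or still open speak of the compounds shown alone.

Compound 1, `CCC(=O)c1ccc2c(c1)sc(=O)n2CCCCCN1CCCCCC1`, gives 12.2 nM in an assay on cell membranes for displacement of a labelled ligand from Sigma non-opioid intracellular receptor 1 (Rattus norvegicus); a higher number here means a weaker inhibitor, a lower number a stronger inhibitor.
Compound 2, `CCCC(=O)c1ccc2c(c1)sc(=O)n2CCCCCN1CCCCCC1`, gives 16.3 nM in this assay.

Compound 2 holds the highest of the two numbers, with compound 1 nearest; the step of a 1.3-fold higher number from compound 1 to compound 2 (0.13 log units; within the scatter) stays within the scatter. Compound 3, `CCCc1ccc2c(c1)sc(=O)n2CCCCCN1CCCCCC1`, differs from compound 2 in one place: propyl in place of propylcarbonyl on an aromatic carbon. For the measured compounds named here, no measured step touches the carbonyl, so nothing seen so far bears directly on this change; the one step seen, a methyl added to the chain, stayed within the scatter. A small shift in this assay is therefore expected, with the direction uncertain. For compound 3 the expected number is 20 nM, between 6 nM and 70 nM. That estimate means a step of a 1.2-fold higher number from compound 2 to compound 3 (0.09 log units; within the scatter) expected for compound 3.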

Compound 3, inhibition constant: 4.6 nM
Beside the measured number, compound 3's estimate is 4.3-fold (0.64 log units) above it; measured number below the stated range.
By their numbers in this assay, from the lowest: compound 3; then compounds 1 and 2 (each within the scatter of the next).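

In this assay replacing propylcarbonyl with propyl on this aromatic carbon gives a 3.5-fold lower number from compound 2 to compound 3 (0.55 log units; beyond the scatter) and replacing propanoyl with propyl gives a 2.7-fold lower number from compound 1 to compound 3 (0.42 log units; beyond the scatter) so the plain chain beats both ketones here. The carbonyl is therefore not required at this position, and changing it moves the number beyond the scatter, which the added chain methyl did not do. Nothing shown explains this gain. On these data alone, whether an amine, a carboxylic acid or a longer plain chain would work as well on this carbon remains open. So does how far a plain chain's length matters here.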